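Notes on the step from compound 3 to compound 4

The compounds below may be only part of what the source reports. "The series", "measured", "known", "first", "only" and "open" are said of these compounds alone.

Measured so far in a functional assay on MCF7 cells (Homo sapiens) for antiproliferative activity, read by MTT assay (a higher number here means a weaker inhibitor, a lower number a stronger inhibitor), on this series:
- compound 1 `COc1cc2c(Oc3ccc(NC(=O)Nc4ccccc4)cc3)ccnc2cc1OCCCCCCC(=O)NO` gives 1040 nM as its value
- compound 2 `COc1cc2c(Oc3ccc(NC(=O)Nc4ccc(OC(F)(F)F)cc4)cc3)ccnc2cc1OCCCCCCC(=O)NO` gives 3200 nM as its value
- compound 3 `COc1cc2c(Oc3ccc(NC(=O)Nc4ccccc4C(F)(F)F)cc3)ccnc2cc1OCCCCCCC(=O)NO` gives 1080 nM as its value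

Compound 3 has two neighbours on these numbers. The closer reading is a 1.0-fold higher number from compound 1 to compound 3 (0.02 log units; within the scatter) and the further one is a 3.0-fold lower number from compound 2 to compound 3 (0.47 log units; beyond the scatter) on the same scale.

The next structure is compound 4 `COc1cc2c(Oc3ccc(NC(=O)Nc4ccc(C)cc4C)cc3)ccnc2cc1OCCCCCCC(=O)NO`, with 2,4-dimethylphenyl in place of 2-(trifluoromethyl)phenyl on an amide-type nitrogen. The difference runs: 2,4-dimethylphenyl in place of 2-(trifluoromethyl)phenyl on an amide-type nitrogen and nothing else changes.

Among the compounds with values here, two measured steps bear on this swap. Trifluoromethyl in place of hydrogen gave a 1.0-fold higher number from compound 1 to compound 3 (0.02 log units; within the scatter) and trifluoromethoxy in place of hydrogen gave a 3.1-fold higher number from compound 1 to compound 2 (0.49 log units; beyond the scatter) as the only modest move. No measured compound carries 2,4-dimethylphenyl, so the size of this step is not shown directly. No step beyond the scatter is expected in this assay for this swap, in either direction.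

The estimated step is a 1.1-fold higher number from compound 3 to compound 4 (0.05 log units; within the scatter) on this reasoning.

Compound 4 is estimated at 1200 nM with an expected range from 550 nM to 2800 nM for a single measurement.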

Compound 4, half-maximal inhibitory concentration: 3430 nM
For compound 4 the middle estimate is 2.9-fold (0.46 log units) below the measured one; measured number outside the range, above it.
By their numbers in this assay, from the lowest: compounds 1 and 3 (each within the scatter of the next); then compounds 2 and 4 (each within the scatter of the next).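

In this assay, the substituents on the phenyl attached to the amide-type nitrogen do not all leave the number unchanged: a 3.3-fold higher number from compound 1 to compound 4 (0.52 log units; beyond the scatter), and a 3.2-fold higher number from compound 3 to compound 4 (0.50 log units; beyond the scatter). The trifluoromethyl of compound 3 therefore gives no general picture of substitution on this ring, since 2,4-dimethylphenyl does not stay with phenyl as 2-(trifluoromethyl)phenyl does. Two different substituted rings also reach the same level, with a 1.1-fold higher number from compound 2 to compound 4 (0.03 log units; within the scatter). Nothing available accounts for these steps.

Which of the two methyl groups carries the step remains open, and a phenyl with a single methyl would be needed to separate them. Also open, on these data alone, is where an amine or a carboxylic acid on this phenyl would fall relative to these four compounds.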